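A few compounds are considered here, and "the series" means these few. Any claim that something is new, unique, unknown or untested is made for them only; others in the source may bear on it.

Of the compounds shown here, three built on one shared core have been tested in a functional assay on MDA-MB-435S cells (Homo sapiens) for antiproliferative activity, read by MTT assay, with a stated time of 72 h; a lower number here means a stronger inhibitor, a higher number a weaker inhibitor. Compound 1 (`Cc1ccc2c(=O)c(CSC(=S)N3CCCCC3)coc2c1`) gives 1700 nM in this assay, the lowest of the two numbers recorded. Compound 3 (`CN1CCN(C(=S)SCc2coc3ccccc3c2=O)CC1`) gives 2200 nM in this assay, a result within the usual scatter of that of compound 1, so the two cannot be separated. Compound 2 (`O=c1cc(CSC(=S)N2CCCC2)oc2ccccc12`) reaches only a limit of the assay, > 30000 nM, with no number behind it; this is the limit of > 30000 nM in this assay, at which 1 of the 3 values shown sits.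

Compound 4 (`Cc1ccc2c(=O)c(CSC(=S)N3CCOCC3)coc2c1`) has not yet been measured. It differs from compound 1 in one place: morpholin-4-yl in place of piperidin-1-yl on a thiocarbonyl carbon. Among the measured compounds shown here, no measured pair shows this exchange, so no step of known size guides the expectation. The change is expected to move the number only slightly, within or just beyond the scatter, toward a weaker inhibitor. Compound 4 is therefore expected to give about 2500 nM in this assay, most likely between 1000 nM and 8000 nM. The expected step is a 1.5-fold higher number from compound 1 to compound 4 (0.17 log units; within the scatter).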

Compound 4, half-maximal inhibitory concentration: 5500 nM
For compound 4 the middle estimate is 2.2-fold (0.34 log units) below the measured one, and the stated range covers the measured number.
By their numbers in this assay, from the lowest: compounds 1 and 3 (each within the scatter of the next); then compound 4. At a limit, above all of these: compound 2.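

This pair gives the first measured view of a change on a thiocarbonyl carbon whose other neighbours are sulfur: in this assay, morpholin-4-yl in place of piperidin-1-yl gives a 3.2-fold higher number from compound 1 to compound 4 (0.51 log units; beyond the scatter) and so counts as a modest loss. Both groups have the same number of heavy atoms, and the entering one has an oxygen in place of a ring carbon and one hydrogen-bond acceptor, so an exchange of a single ring atom is enough to move the number beyond the scatter. Among the compounds shown here, nothing measured so far explains why this exchange has that effect.

From the compounds shown here alone, whether a step of this size would also appear on other cores remains open. So does the effect of an open-chain dimethylamino group or a thiomorpholin-4-yl ring on the same thiocarbonyl carbon.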